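Aryl Urea Variation on a Quinoline Diamine Core

The source may report more compounds than this note shows. Statements on the series, on what has been measured and on what is new or still open speak of the compounds shown alone.

Measured compounds:
compound 1 `COc1cc(NC(C)CCCNC(=O)Nc2ccc(C(F)(F)F)cc2)c2ncccc2c1` gives 22000 nM
compound 2 `COc1cc(NC(C)CCCNC(=O)Nc2ccc(O)cc2)c2ncccc2c1` gives 30000 nM
compound 3 `COc1cc(NC(C)CCCNC(=O)NNC(=O)Nc2cccc(C(F)(F)F)c2)c2ncccc2c1` gives 21000 nM

All three values come from a functional assay on SW-620 cells (Homo sapiens) for inhibition, read by MTT assay, with a stated time of 72 h; a lower number here means a stronger inhibitor, a higher number a weaker inhibitor. Compound 3 has the lowest of the three numbers, but its distance to compound 1 and to compound 2 both lie within the scatter, so nothing separates the three compounds on these data.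

Going by the values given here, the one step measured within one place, a 1.4-fold higher number from compound 1 to compound 2 (0.13 log units; within the scatter), concerns a hydroxy in place of a trifluoromethyl on an aromatic carbon and stays within the scatter. Among the compounds with values here, it is the only guide to how a change on the terminal aryl ring reads in this assay.

Compound 4 `COc1cc(NC(C)CCCNC(=O)NNC(=O)Nc2ccc(F)cc2)c2ncccc2c1` is not yet measured. It differs from compound 3 by 4-fluorophenyl in place of 3-(trifluoromethyl)phenyl on an amide-type nitrogen; cut one bond further out, the same difference reads (3-(trifluoromethyl)phenyl)amino to (4-fluorophenyl)amino. The measured step from compound 1 to compound 2, which also exchanges a trifluoromethyl on the terminal ring, gave no movement beyond the scatter, so the step is expected to be small, a 1.2-fold higher number from compound 3 to compound 4 (0.08 log units; within the scatter), with no direction claimed.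

On that basis compound 4 is estimated at 25000 nM, with a range from 10000 nM to 60000 nM.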

Compound 4, half-maximal inhibitory concentration: > 100000 nM
Compound 4: no number, only a limit; the forecaster's own chance of this, stated with the estimate: 10%; at least 4.0-fold (0.60 log units) between middle value and limit.
By their numbers in this assay, from the lowest: compounds 3, 1 and 2 (each within the scatter of the next). At a limit, above all of these: compound 4.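

Compound 4 stands at > 100000 nM in this assay, which is a limit of the assay and not a number: the limit of > 100000 nM in this assay, at which 1 of the 4 values shown sits.

Moving from 3-(trifluoromethyl)phenyl to 4-fluorophenyl on an amide-type nitrogen gives an at least 4.7-fold higher number from compound 3 to compound 4 (0.67 log units; beyond the scatter), so this terminal aryl group can shift the reading beyond the scatter, whereas the earlier change on a terminal ring, a 1.4-fold higher number from compound 1 to compound 2 (0.13 log units; within the scatter), stayed within it. The same limit also places compound 4 apart from the two compounds with a single urea, through an at least 3.3-fold higher number from compound 2 to compound 4 (0.52 log units; beyond the scatter) and an at least 4.5-fold higher number from compound 1 to compound 4 (0.65 log units; beyond the scatter), although these two steps exchange a ((4-fluorophenyl)carbamoyl)amino group for a whole aryl group and so do not isolate the ring change.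

The step from compound 3 changes both the substituent and its place on the ring, and the compounds shown do not tell which of the two matters; a 4-(trifluoromethyl)phenyl on the same amide-type nitrogen would begin to separate them. Also open, from the compounds shown here alone, is how an amine or a carboxylic acid in place of the fluorine would read in this assay.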